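The source may report more compounds than this note shows. Statements on the series, on what has been measured and on what is new or still open speak of the compounds shown alone.

Three compounds have been measured so far in a physicochemical assay for solubility, at pH 7.4 (a higher number here means a more soluble compound, a lower number a less soluble compound), and a fourth still awaits its number:

- compound 1 `COCc1nc(Nc2ccc(C(F)(F)F)cc2)c2ccc(-c3ncccc3C(F)(F)F)cc2n1` gives 0.2 ug/mL
- compound 2 `CC(C)OCc1nc(Nc2ccc(C(F)(F)F)cc2)c2ccc(-c3ncccc3C(F)(F)F)cc2n1` gives 0.04 ug/mL
- compound 3 `OCCc1nc(Nc2ccc(C(F)(F)F)cc2)c2ccc(-c3ncccc3C(F)(F)F)cc2n1` gives 0.02 ug/mL
- compound 4 `O=C(O)CCc1nc(Nc2ccc(C(F)(F)F)cc2)c2ccc(-c3ncccc3C(F)(F)F)cc2n1` has not yet been measured

Compound 3 stands at the low end of this short series, level within the scatter with compound 2 and well under compound 1. Compound 4 differs from it at the end of the chain (carboxy in place of hydroxy on a saturated chain carbon, two bonds along the chain from an aromatic carbon), with carboxy in place of hydroxy on a saturated chain carbon, two bonds along the chain from an aromatic carbon.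

Among the measured compounds shown here, three measured steps bear on this change, though only loosely: a 5.0-fold lower number from compound 1 to compound 2 (0.70 log units; beyond the scatter), a 10-fold lower number from compound 1 to compound 3 (1.00 log units; beyond the scatter) and a 2.0-fold lower number from compound 2 to compound 3 (0.30 log units; within the scatter). The first two are modest and the third stays within the scatter. All three alter the same chain on the shared core, but none brings in a carboxy group, so they fix no size for this change. A move to a higher number in this assay is nevertheless expected, larger than those steps and quite uncertain. The expected change is an estimate only (a 100-fold higher number from compound 3 to compound 4 (2.00 log units; beyond the scatter)). The estimate for compound 4 is 2 ug/mL (expected range 0.1 ug/mL to 40 ug/mL).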

Compound 4, solubility: 125 ug/mL
Compound 4: middle estimate off by 63-fold (1.80 log units), on the low side, and the stated range ends below it.
By their numbers in this assay, from the lowest: compounds 3 and 2 (each within the scatter of the next); then compound 1; then compound 4.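

In this assay, carboxy in place of hydroxy on a saturated chain carbon, two bonds along the chain from an aromatic carbon, gives a 6300-fold higher number from compound 3 to compound 4 (3.80 log units; beyond the scatter) and is a large step, whereas the earlier changes to this chain were modest or within the scatter and all ran downward from compound 1. The other two new comparisons agree, with a 3100-fold higher number from compound 2 to compound 4 (3.49 log units; beyond the scatter) and a 630-fold higher number from compound 1 to compound 4 (2.80 log units; beyond the scatter) both large, so this chain on the shared core can carry the number far upward as well as down, and compound 4 stands beyond the scatter of all three earlier compounds. Nothing available here accounts for the size of this rise.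

The compounds shown do not settle whether the rise belongs to the carboxy group alone, or whether an amine, a primary amide or a tetrazole on the same chain would give a similar number. They also leave open how a shorter or longer chain carrying the carboxy group would read, and whether the step would keep its size on a different core.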